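The source may report more compounds than this note shows. Statements on the series, on what has been measured and on what is new or still open speak of the compounds shown alone.

Measured so far in an assay on CHO cells for displacement of a labelled ligand from adenosine receptor A1 (Homo sapiens), read by scintillation counting, tested at 10 uM; a lower number here means less inhibition, a higher number more inhibition at the concentration tested (going by the name of the read-out):
compound 1 `CC(C)(C)Cc1c(-c2ccc(Cl)cc2)sc(N)c1C(=O)c1ccc(Cl)cc1`; compound 1 gives 1%
compound 2 `CC(C)(C)Cc1c(-c2ccc(Cl)c(Cl)c2)sc(N)c1C(=O)c1ccc(Cl)cc1`; compound 2 gives 1%
compound 3 `CC(C)(C)Cc1c(Br)sc(N)c1C(=O)c1cccc(Cl)c1`; compound 3 gives 1%

Compounds 1 and 2 share one core and differ by chloro in place of hydrogen on an aromatic carbon; that change produced no change at the digits printed from compound 1 to compound 2 (within the scatter). Compound 3 has a different core; the difference between the core of compound 1 and the core of compound 3 is not broken down here, and the two values simply stand level. Compound 4 `CC(C)(C)Cc1c(Br)sc(N)c1C(=O)c1ccc(Cl)c(Cl)c1` is not yet measured in this assay and differs from compound 3 by chloro in place of hydrogen on an aromatic carbon. The entering chloro is meta to a large group in compound 2 but para to a large group in compound 4, so this is the same kind of change, not the same one. The expected step from compound 3 is a number 1 percentage points higher from compound 3 to compound 4 (within the scatter), resting on the earlier change giving no change at the digits printed from compound 1 to compound 2 (within the scatter) and on compound 3 sitting at 1%. For compound 4 the estimate in this assay is 2%, expected to lie between -6% and 12%.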

Compound 4, a percentage reported as inhibition, at one concentration (the size of the read-out at that concentration, not a potency): 1%
For compound 4 the middle estimate is 1 percentage points above the measured one; measured number inside the range.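

In this assay, chloro in place of hydrogen on an aromatic carbon gives no change at the digits printed from compound 3 to compound 4 (within the scatter), and this step matches the earlier one on the other core: the same change on two cores in this assay, no change at the digits printed (within the scatter) from compound 1 to compound 2 and no change at the digits printed (within the scatter) from compound 3 to compound 4, 0 percentage points apart, within the scatter of two such steps. Across these two cores, the change leaves this read-out level. Among these compounds, this does not show how the change behaves on a compound with clear inhibition, as both pairs sit at the same very low level and each core offers only one step.

On these data alone, whether a different group on the same aromatic carbon, such as a methoxy, an amine or a carboxylic acid, would move the read-out remains open. The same question stands for a longer chain on either core.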